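Compound 3: replacing the 2-(hydroxymethyl)pyrrolidin-1-yl group

A few compounds are considered here, and "the series" means these few. Any claim that something is new, unique, unknown or untested is made for them only; others in the source may bear on it.

In a functional assay on PC-3 cells (Homo sapiens) for inhibition, read by MTT assay, with a stated time of 48 h, tested at 10 uM (on this read-out higher numbers stand for more inhibition of growth at the one concentration tested and lower numbers for less inhibition of growth), compound 1 (`Cc1cc(=O)c2c(O)c(CN3CCCC3)c(O)c([C@H]3CCN(C)C[C@H]3O)c2o1`) gives 10% and compound 2 (`Cc1cc(=O)c2c(O)c(CN3CCCC3CO)c(O)c([C@H]3CCN(C)C[C@H]3O)c2o1`) gives 15%. Going by the values given here, the two values lie within the scatter of each other, so compound 2 stands level with the only other number.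

Compound 3 (`Cc1cc(=O)c2c(O)c(CN(C)CC(=O)O)c(O)c([C@H]3CCN(C)C[C@H]3O)c2o1`) keeps the shared core and changes one group: (carboxymethyl)(methyl)amino in place of 2-(hydroxymethyl)pyrrolidin-1-yl on a saturated chain carbon bound to an aromatic carbon. This places (carboxymethyl)(methyl)amino in place of 2-(hydroxymethyl)pyrrolidin-1-yl on a saturated chain carbon bound to an aromatic carbon.

Among the compounds with values here, one measured step bears on this group: a number 5 percentage points higher from compound 1 to compound 2 (within the scatter), with hydroxymethyl in place of hydrogen on a saturated ring carbon. It is small, but it covers only that addition. Within the data shown here, no measured compound carries the carboxymethyl group or lacks the ring, so the data set no direction for the change. No step beyond the scatter is expected in this assay, though the uncertainty stays wide.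

The estimated step is a number 3 percentage points lower from compound 2 to compound 3 (within the scatter). For compound 3 the expected value is 12%, with an estimated range of 0% to 30%.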

Compound 3, percent growth inhibition at one concentration: 20%
Compound 3: middle estimate off by 8 percentage points, on the low side, within the range that was stated.
By their numbers in this assay, from the lowest: compounds 1, 2 and 3 (each within the scatter of the next).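

In this assay, the saturated chain carbon bound to an aromatic carbon now carries a group with no ring, and the reading stays within the scatter: a number 5 percentage points higher from compound 2 to compound 3 (within the scatter). The same holds against the unsubstituted ring, with a number 10 percentage points higher from compound 1 to compound 3 (within the scatter), so all three groups read alike here and none can be ranked above another. The earlier pair covered only the addition of hydroxymethyl to an intact ring, whereas this result extends the level readings to the full exchange of the ring for an open chain ending in a carboxylic acid, and no independent data bear on why these groups read alike.

The compounds shown leave open whether any group at this place can move growth inhibition beyond the scatter, for example a simple dimethylamino group, a morpholin-4-yl or 4-methylpiperazin-1-yl ring, or a longer chain ending in a carboxylic acid. They also leave open whether the methyl ester of the carboxymethyl group, or a primary amide in its place, would read level with compound 3.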